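This account rests on a few compounds, and the source may have more. Where it says the series, first, only, none or still open, it means among the compounds named here.

In an ADME assay on GES1 cells (Homo sapiens) for cytotoxicity, read by MTT assay, with a stated time of 24 h (on this read-out lower numbers stand for higher toxicity in this test and higher numbers for lower toxicity in this test), three members of this series have been examined, all sharing the core of compound 1, `O=c1[nH]cc(S(=O)(=O)Nc2ccccc2-c2cn(-c3ccccc3F)nn2)c(=O)[nH]1`. Compound 1 yields only a limit of the assay, > 100000 nM, and no number. Compound 2, `O=c1[nH]cc(S(=O)(=O)Nc2ccccc2-c2cn(-c3cccc(F)c3)nn2)c(=O)[nH]1`, is recorded as "not toxic" (no number reported), again without a figure. Within the data shown here, compound 3, `Cc1cccc(-n2cc(-c3cccc(NS(=O)(=O)c4c[nH]c(=O)[nH]c4=O)c3)nn2)c1`, is the sole member with a measured value: in this assay compound 3 gives 18500 nM. Compound 3 therefore stands as the only quantified point, with one further value resting at a limit, (the limit of > 100000 nM in this assay, at which 1 of the 3 values shown sits), and one entry given in words alone.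

The step to be followed runs from compound 3 to compound 4, `O=c1[nH]cc(S(=O)(=O)Nc2cccc(-c3cn(-c4cccc(F)c4)nn3)c2)c(=O)[nH]1`. The change is fluoro in place of methyl on an aromatic carbon; cut one bond further out it reads as 3-methylphenyl to 3-fluorophenyl. Among the measured compounds shown here, no step between two measured compounds exists in this set, so there is no measured precedent. Still, the two compounds bearing a fluorophenyl group, compound 1 and compound 2, show no quantifiable toxicity within the range tested. On that basis the step from compound 3 to compound 4 is expected to move toward lower toxicity in this assay, a 2.2-fold higher number from compound 3 to compound 4 (0.33 log units; beyond the scatter), possibly beyond the scatter, though the thin record keeps this uncertain. Compound 4 is accordingly estimated at 40000 nM, with a range from 12000 nM to 150000 nM.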

Compound 4, half-maximal cytotoxic concentration: "not toxic" (no number reported)
Compound 4: no number reported; the estimate stays without a comparison.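

In this assay, among these compounds, compound 4 is recorded as "not toxic", in words alone, so no step from compound 3 to compound 4 can be read. The compounds shown leave open how far, in numbers, the 3-fluorophenyl compound 4 lies from the 3-methylphenyl compound 3, which gives 18500 nM, the only figure in the set.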